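This account rests on a few compounds, and the source may have more. Where it says the series, first, only, none or still open, it means among the compounds named here.

Measured compounds:
compound 1 `CN(C)CCCN(Cc1ccccc1)c1ccc(C(=O)N2CCc3ccc(OS(N)(=O)=O)cc3C2)cc1`: 61.6%
compound 2 `CC(C)CCN(CCC(C)C)c1ccc(C(=O)N2CCc3ccc(OS(N)(=O)=O)cc3C2)cc1`: 90.8%

In an assay on HEK293 cells for inhibition of Steryl-sulfatase (Homo sapiens), tested at 1 uM (a higher number here means a stronger effect of the compound at the concentration tested, a lower number a weaker effect), compound 1 gives 61.6%, the lowest of the two numbers; compound 2 stands higher by a margin beyond the scatter. Compound 3 `CN(C)CCN(Cc1ccccc1)c1ccc(C(=O)N2CCc3ccc(OS(N)(=O)=O)cc3C2)cc1` has not yet been measured. It differs from compound 1 in one place: dimethylamino in place of (dimethylamino)methyl on a saturated chain carbon, two bonds along the chain from a nitrogen on an aromatic ring. Among the compounds with values here, no measured pair shows a step of this kind, so its size is unknown. The expected change is a number 1.6 percentage points lower from compound 1 to compound 3 (within the scatter), no larger than the usual scatter in either direction. Compound 3 is therefore estimated at 60%, with a range from 40% to 80%.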

Compound 3, a percentage reported as inhibition, at one concentration (the size of the read-out at that concentration, not a potency): 57.8%
Beside the measured number, compound 3's estimate is 2.2 percentage points above it; low and high end bracket the measured number.
By their numbers in this assay, from the lowest: compounds 3 and 1 (each within the scatter of the next); then compound 2.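

In this assay, putting dimethylamino in place of (dimethylamino)methyl on a saturated chain carbon, two bonds along the chain from a nitrogen on an aromatic ring, gives a number 3.8 percentage points lower from compound 1 to compound 3 (within the scatter). At this position, then, the 3-(dimethylamino)propyl and 2-(dimethylamino)ethyl chains are not told apart by this read-out at the concentration tested. No measurement is available that bears on this result.

The compounds shown leave open whether a longer chain would read differently here. They also leave open the effect of a piperidine or a carboxylic acid in place of the terminal dimethylamino.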